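Swapping Methyl for Trifluoromethyl: What to Expect

A few compounds are considered here, and "the series" means these few. Any claim that something is new, unique, unknown or untested is made for them only; others in the source may bear on it.

Among the compounds with values here, in an assay on HEK293 cells for inhibition of Leucine-rich repeat serine/threonine-protein kinase 2 (Homo sapiens), with a stated time of 48 h (a lower number here means a stronger inhibitor, a higher number a weaker inhibitor), compound 2 `Cc1nn(C)cc1Nc1nc(N)c2c(C#N)c(N3CCC[C@H]3C)n(C)c2n1` gives 190 nM, the lowest of the two numbers measured so far. Compound 1 `Cc1nn(CC2(O)COC2)cc1Nc1nc(N)c2c(C#N)c(N3CCC[C@H]3C)n(C)c2n1` gives 410 nM; the step of a 2.2-fold lower number from compound 1 to compound 2 (0.33 log units; beyond the scatter) came from a change at a different place on the shared core. Compound 3 `C[C@@H]1CCCN1c1c(C#N)c2c(N)nc(Nc3cn(C)nc3C(F)(F)F)nc2n1C` differs from compound 2 at yet another site: trifluoromethyl in place of methyl on an aromatic carbon. Within the data shown here, no measured step shows this exchange, so the data give no direct guide to its effect. The step of a 1.1-fold higher number from compound 2 to compound 3 (0.02 log units; within the scatter) is expected to stay within the scatter. The estimate for compound 3 is 200 nM, with a range from 80 nM to 500 nM.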

Compound 3, half-maximal inhibitory concentration: 910 nM
For compound 3 the middle estimate is 4.6-fold (0.66 log units) below the measured one; the measured number lies above the stated range.
By their numbers in this assay, from the lowest: compound 2; then compound 1; then compound 3.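

This position on the five-membered aromatic ring is sensitive to what it carries: trifluoromethyl in place of methyl gives a 4.8-fold higher number from compound 2 to compound 3 (0.68 log units; beyond the scatter) and so a weaker inhibitor. Within the data shown here, the earlier step concerned a different site, so this is the first view of how a change here behaves. Nothing measured here explains the rise. Going by these compounds, whether hydrogen, chlorine or ethyl at this carbon would keep the number of compound 2 stays open. So does whether the same exchange would cost as much with the 3-hydroxyoxetan-3-yl group of compound 1 in place.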